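This account rests on a few compounds, and the source may have more. Where it says the series, first, only, none or still open, it means among the compounds named here.

Compound 3 `CC(C)C(=O)Nc1ccc(S(=O)(=O)Oc2ccccc2I)cc1` carries an isopropylcarbonyl on the amide-type nitrogen of the shared core and an iodo group on an aromatic carbon. In a functional assay on HT-1080 cells (Homo sapiens) for antiproliferative activity, read by sulforhodamine B assay, with a stated time of 48 h (on this read-out higher numbers stand for weaker inhibition and lower numbers for stronger inhibition), compound 3 gives 3300 nM, the lowest of the three numbers recorded: compound 2 `CC(C)C(=O)Nc1ccc(S(=O)(=O)Oc2ccccc2C(C)C)cc1` gives 4900 nM, a gap within the scatter, while compound 1 `CC(=O)Nc1ccc(S(=O)(=O)Oc2ccccc2C(C)C)cc1` gives 12000 nM, a gap beyond it. Compound 4 `CCCCCNC(=O)Nc1ccc(S(=O)(=O)Oc2ccccc2I)cc1` differs from compound 3 by pentylamino in place of isopropyl on a carbonyl carbon. Of the measured steps, only a 2.4-fold lower number from compound 1 to compound 2 (0.39 log units; beyond the scatter) touches the same carbonyl carbon; a 1.5-fold lower number from compound 2 to compound 3 (0.17 log units; within the scatter) alters an aromatic carbon instead. The single change at that carbonyl carbon lowered the number, but a pentylamino group there has no precedent among these compounds. Compound 4 is therefore expected to show only a modest shift, a 1.3-fold lower number from compound 3 to compound 4 (0.12 log units; within the scatter), with an estimate of 2500 nM and a range of 800 nM to 8000 nM.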

Compound 4, half-maximal inhibitory concentration: 6900 nM
Compound 4: the middle estimate sits 2.8-fold (0.44 log units) below what was measured; measured number inside the range.
By their numbers in this assay, from the lowest: compounds 3, 2, 4 and 1 (each within the scatter of the next, the first and the last beyond it).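

At this carbonyl carbon the number can rise as well as fall: in this assay, pentylamino in place of isopropyl gives a 2.1-fold higher number from compound 3 to compound 4 (0.32 log units; beyond the scatter), whereas isopropyl in place of methyl gave a 2.4-fold lower number from compound 1 to compound 2 (0.39 log units; beyond the scatter). The new step brings in a nitrogen with its hydrogen-bond donor and a longer chain together, and these two changes cannot be told apart here. No available evidence accounts for the rise.

Open, going by these compounds, is whether a hexyl chain without the nitrogen, or a shorter ethylamino group, would behave like pentylamino at this carbon. Also open, on these data alone, is how pentylamino behaves with isopropyl rather than iodo on the aromatic carbon.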